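The compounds below may be only part of what the source reports. "The series", "measured", "known", "first", "only" and "open" are said of these compounds alone.

Measured compounds in an assay on isolated protein for binding affinity to 5-hydroxytryptamine receptor 3A (Homo sapiens); on this read-out lower numbers stand for stronger inhibition and higher numbers for weaker inhibition:
compound 1, `CS(=O)(=O)N1CCN(CC(O)CN2CCC(CNC(=O)c3cccc4[nH]cnc34)CC2)CC1`: 50100 nM
compound 2, `CS(=O)(=O)N1CCN(CC(O)CN2CCC(NC(=O)c3cccc4[nH]cnc34)CC2)CC1`: 63100 nM

Compound 1 has the lower of the two numbers in this assay, but the value of compound 2 lies within the usual scatter of it, so the two cannot be told apart on these data. Both sit far up the scale, at the weak end of what this assay resolves.

Compound 3, `CCc1nc2c(C(=O)NCC3CCN(CC(O)CN4CCN(S(C)(=O)=O)CC4)CC3)cccc2[nH]1`, differs from compound 1 in one place: ethyl in place of hydrogen on an aromatic carbon. Within the data shown here, no pair of measured compounds shows what this exchange does, so the step from compound 1 to compound 3 has no precedent here. Among the measured compounds shown here, with only two weak and indistinguishable values to go on, the expected step of a 1.1-fold lower number from compound 1 to compound 3 (0.05 log units; within the scatter) is none beyond the scatter. Compound 3 is therefore estimated at 45000 nM, with a range from 12000 nM to 170000 nM.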

Compound 3, inhibition constant: 79400 nM
Compound 3: middle estimate off by 1.8-fold (0.25 log units), on the low side; measured number inside the range.
By their numbers in this assay, from the lowest: compounds 1, 2 and 3 (each within the scatter of the next).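

In this assay, ethyl in place of hydrogen on the aromatic carbon between two ring nitrogen atoms gives a 1.6-fold higher number from compound 1 to compound 3 (0.20 log units; within the scatter) and so leaves compound 3 indistinguishable from compound 1 on these data. Among these compounds, this is the first reading with a group other than hydrogen at this place, and it shows that ethyl can sit there without a step beyond the scatter, although all three compounds stay at the weak end of what this assay resolves. No separate evidence bears on this result.

On these data alone, it remains open whether another group at this carbon, such as methyl, an amine or a phenyl ring, would move the number beyond the scatter from compound 1. As far as these compounds go, it is also open whether ethyl at the same place on compound 2 would give a similar step.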